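This account rests on a few compounds, and the source may have more. Where it says the series, first, only, none or still open, it means among the compounds named here.

Going by the values given here, compound 2 `CC(C)N(CCN(C(=O)Nc1cccc(F)c1)C1CC[C@]2(c3cccc(C#N)c3)CC2C1)C(C)C` gives the lower of the two numbers measured so far in a functional assay for antagonist activity at melanin-concentrating hormone receptor 1 (Homo sapiens); a higher number here means a weaker inhibitor, a lower number a stronger inhibitor: in this assay compound 2 gives 2.1 nM, while its only measured neighbour, compound 1 `CC(C)N(CCN(C(=O)Nc1ccc(F)c(Cl)c1)C1CC[C@]2(c3cccc(C#N)c3)CC2C1)C(C)C`, gives 4.98 nM. Among the compounds with values here, that neighbour sets the one step in hand, the change a 2.4-fold lower number from compound 1 to compound 2 (0.38 log units; beyond the scatter), which shows the number falling once the 3-chloro-4-fluorophenyl ring is exchanged for 3-fluorophenyl. Compound 3 `CC(C)N(CCN(C(=O)Nc1cccc(Cl)c1)C1CC[C@]2(c3cccc(C#N)c3)CC2C1)C(C)C` returns part of the way: the difference is chloro in place of fluoro on an aromatic carbon, placed on an aromatic carbon of the six-membered aromatic ring of carbon only, meta to a large group. Within the data shown here, no measured pair isolates this single halogen exchange, so the bearing of compound 1 is only indirect. Compound 3 is therefore expected to show a modest rise, a 1.7-fold higher number from compound 2 to compound 3 (0.22 log units; within the scatter), with compound 3 estimated at 3.5 nM in this assay, within a range of 1.5 nM to 8 nM.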

Compound 3, inhibition constant: 6 nM
For compound 3 the middle estimate is 1.7-fold (0.23 log units) below the measured one, within the range that was stated.
By their numbers in this assay, from the lowest: compound 2; then compounds 1 and 3 (each within the scatter of the next).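

The exchange of 3-fluorophenyl for 3-chlorophenyl now stands alone as a single change, and in this assay it gives a 2.9-fold higher number from compound 2 to compound 3 (0.46 log units; beyond the scatter), so the two halogens can be told apart at this place on the ring. Taking away the fluoro that compound 1 carries on its 3-chloro-4-fluorophenyl ring gives a 1.2-fold higher number from compound 1 to compound 3 (0.08 log units; within the scatter), so that fluoro leaves no mark that can be separated from the scatter, and the difference between compound 1 and compound 2 follows the chloro-to-fluoro exchange in these compounds. Nothing available accounts for the difference between the two halogens.

As far as these compounds go, it remains open how an unsubstituted phenyl ring would compare with these halogenated rings. Also open, from the compounds shown here alone, is whether bromo, methyl, methoxy or trifluoromethyl at the same place would extend this trend or break it.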